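Azole swap at the branched carbon of an EP3 antagonist series

This account rests on a few compounds, and the source may have more. Where it says the series, first, only, none or still open, it means among the compounds named here.

Measured compounds:
compound 1, `CCC(CC)(c1nnc[nH]1)c1ccc(-c2ccc3cc(F)cc(F)c3c2)[nH]c1=O`, 350 nM
compound 2, `CCn1ncc2c(F)cc(-c3ccc(C(CC)(CC)c4nncn4C)c(=O)[nH]3)cc21`, 120 nM
compound 3, `Cc1nc(C(c2ccc(-c3ccc4cccc(F)c4c3)[nH]c2=O)C(C)C)[nH]c1C`, 50 nM

In a functional assay on CHO cells for antagonist activity at prostaglandin E2 receptor EP3 subtype (Homo sapiens), read by cAMP accumulation (on this read-out lower numbers stand for stronger inhibition and higher numbers for weaker inhibition), compound 3 gives the lowest number of the three, and its steps to compound 2 and to compound 1 both lie beyond the scatter, so compound 3 is the strongest inhibitor among those measured. Compound 4, `CC(C)C(c1noc(=O)[nH]1)c1ccc(-c2ccc3cccc(F)c3c2)[nH]c1=O`, differs from compound 3 only in the azole: a group of 6 heavy atoms (2 carbon, 2 nitrogen, 2 oxygen; one five-membered aromatic ring with 3 hetero atoms) in place of a group of 7 heavy atoms (5 carbon, 2 nitrogen; one five-membered aromatic ring with 2 hetero atoms), on a saturated chain carbon bound to an aromatic carbon and a saturated chain carbon. Within the data shown here, no measured pair isolates this change, so the size of the step rests on no direct precedent. The expected step of a 3.0-fold higher number from compound 3 to compound 4 (0.48 log units; beyond the scatter) in this assay is toward weaker inhibition, by more than the scatter. Compound 4 is estimated at 150 nM, with a range from 50 nM to 500 nM.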

Compound 4, half-maximal inhibitory concentration: 41 nM
Compound 4: the middle estimate sits 3.7-fold (0.56 log units) above what was measured; measured number below the stated range.
By their numbers in this assay, from the lowest: compounds 4 and 3 (each within the scatter of the next); then compound 2; then compound 1.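

In this assay, the azole exchange on the saturated chain carbon gives a 1.2-fold lower number from compound 3 to compound 4 (0.09 log units; within the scatter), so this position accepts the 4,5-dimethyl-1H-imidazol-2-yl group and a ring of 6 heavy atoms with 3 hetero atoms alike. The two groups each carry 1 hydrogen-bond donor, while the count of acceptors goes from 1 to 3 with no step beyond the scatter in this pair. Nothing measured here bears on why the two groups read alike.

Going by these compounds, whether a carboxylic acid or an unsubstituted imidazole on this carbon would read the same stays open.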